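Bromo to methyl on the aryl of the triazole series

This account rests on a few compounds, and the source may have more. Where it says the series, first, only, none or still open, it means among the compounds named here.

Measured compounds:
compound 1: `O=C1O[C@H]([C@@H](O)Cn2cc(-c3ccc(Br)cc3)nn2)C(OCc2ccccc2)=C1OCc1ccccc1` — 3910 nM
compound 2: `COc1ccc(-c2cn(C/C=C3\OC(=O)C(OCc4ccccc4)=C3OCc3ccccc3)nn2)cc1` — > 100000 nM

Within the data shown here, in a functional assay on HeLa cells (Homo sapiens) for antiproliferative activity, read by MTT assay, with a stated time of 72 h (on this read-out lower numbers stand for stronger inhibition and higher numbers for weaker inhibition), compound 1 gives 3910 nM and is the only compound of the series with a numerical value. Compound 2 gives > 100000 nM, which is a limit of the assay and not a number; this is the limit of > 100000 nM in this assay, at which 1 of the 2 values shown sits. Among the measured compounds shown here, compound 1 and compound 2 differ in more than one place, so their two values show only that one is a number and the other a limit.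

Compound 3 is `Cc1ccc(-c2cn(C[C@H](O)[C@H]3OC(=O)C(OCc4ccccc4)=C3OCc3ccccc3)nn2)cc1`, not yet measured. It differs from compound 1 by methyl in place of bromo on an aromatic carbon. For the measured compounds named here, no step between measured compounds covers this change, so the expectation rests on compound 1 alone. The step of a 1.3-fold higher number from compound 1 to compound 3 (0.11 log units; within the scatter) is expected to be small, within the usual scatter, without a clear direction. Compound 3 is therefore estimated at 5000 nM, with a range of 1500 nM to 20000 nM.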

Compound 3, half-maximal inhibitory concentration: 25500 nM
The estimate for compound 3 lay 5.1-fold (0.71 log units) below the measured number; measured number above the stated range.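

Among these compounds, exchanging 4-bromophenyl for 4-methylphenyl gives in this assay a 6.5-fold higher number from compound 1 to compound 3 (0.81 log units; beyond the scatter) and is the first change that can be read at a single place. A swap of one heavy atom for one heavy atom, on an aromatic carbon para to a large group, is thus enough to move the read-out beyond the scatter, so this position is not indifferent to its substituent. Bromo gives the lower number of the two groups, but no measured property among the data accounts for the step.

The compounds shown leave open whether chloro, fluoro or trifluoromethyl on this aromatic carbon would read closer to compound 1 or to compound 3. Equally open, on these data alone, is how an amine or a carboxylic acid at the same place would read.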